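Amine chain variation in a corticotropin-releasing factor receptor series

A few compounds are considered here, and "the series" means these few. Any claim that something is new, unique, unknown or untested is made for them only; others in the source may bear on it.

Measured compounds:
- compound 1 `CCCN(Cc1c(C(F)(F)F)nc2n(-c3c(C)cc(C)cc3C)c(Cl)cn12)CC1CCC1`: 5.3 nM
- compound 2 `Cc1cc(C)c(-n2c(Cl)cn3c(CN(CCC(F)(F)F)Cc4ccc(Cl)cc4)c(C(F)(F)F)nc23)c(C)c1`: 12 nM

Both compounds share one core and differ in the two groups on the amine nitrogen. In an assay on cells for displacement of a labelled ligand from corticotropin-releasing factor receptor 1 (Homo sapiens), with a stated time of 100 min (a higher number here means a weaker inhibitor, a lower number a stronger inhibitor), compound 1 gives 5.3 nM. In this assay compound 2 gives 12 nM, the higher of the two numbers; its nearest neighbour is compound 1, whose number is lower by a margin beyond the usual scatter. Among the compounds with values here, no pair measured so far differs in only one place, so no measured single step is available.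

Compound 3 `CCCN(Cc1ccc(Cl)cc1)Cc1c(C(F)(F)F)nc2n(-c3c(C)cc(C)cc3C)c(Cl)cn12` is not yet measured. It differs from compound 2 in one place: methyl in place of trifluoromethyl on a saturated chain carbon, two bonds along the chain from an amine nitrogen. Compound 3 thus carries the same propyl chain found in compound 1 together with the chlorobenzyl group of compound 2.

Within the data shown here, with no measured step for this change, the expected step in this assay from compound 2 to compound 3 is a 1.5-fold lower number from compound 2 to compound 3 (0.18 log units; within the scatter), a modest move towards a lower number, not far beyond the scatter. For compound 3 the estimate in this assay is 8 nM, with an expected range from 3 nM to 25 nM.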

Compound 3, inhibition constant: 28 nM
The estimate for compound 3 lay 3.5-fold (0.54 log units) below the measured number; measured number outside the range, above it.
By their numbers in this assay, from the lowest: compound 1; then compound 2; then compound 3.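

In this assay, within the data shown here, the change from 3,3,3-trifluoropropyl to propyl, with the other group on the amine nitrogen held constant, gives a 2.3-fold higher number from compound 2 to compound 3 (0.37 log units; beyond the scatter), the first single-place reading at this chain position, and here the trifluoromethyl end carries the lower number. The second group on that nitrogen also registers on its own: with the propyl chain held constant, 4-chlorophenyl in place of cyclobutyl on a saturated chain carbon bound to an amine nitrogen gives a 5.3-fold higher number from compound 1 to compound 3 (0.72 log units; beyond the scatter), a step likewise beyond the scatter. No measurement is available that bears on the origin of either step.

From the compounds shown here alone, each step rests on a single pair, so it remains open whether the trifluoromethyl result carries over to the cyclobutyl side of the series, or whether the two changes simply add. Going by these compounds, how a difluoromethyl end, a longer chain or a terminal ether on this chain would compare with propyl and 3,3,3-trifluoropropyl also remains open.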